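Swapping the fluorines for chlorines on compound 3's phenyl ring

This account rests on a few compounds, and the source may have more. Where it says the series, first, only, none or still open, it means among the compounds named here.

Of the compounds shown here, three sharing one core have been tested in a functional assay on CHO cells with adenosine receptor A1 (Homo sapiens) as the target, read by cAMP accumulation and immunoassay, with a stated time of 6 min, tested at 1 uM; a higher number here means a weaker effect of the compound at the concentration tested, a lower number a stronger effect. Compound 1 `CC(C)N1CCN(Cc2csc(N)c2C(=O)c2ccc(Cl)cc2)CC1` gives 7.3%, and compound 2 `Nc1scc(CN2CCN(c3cccc4ccccc34)CC2)c1C(=O)c1ccc(Cl)cc1` gives 2.9%, the two lying close, as a number 4.4 percentage points lower from compound 1 to compound 2 (within the scatter) shows. Compound 3 `Nc1scc(CN2CCN(c3ccc(F)cc3F)CC2)c1C(=O)c1ccc(Cl)cc1` gives -66%, the lowest number of the three; the gaps are a number 73.3 percentage points lower from compound 1 to compound 3 (beyond the scatter) and a number 68.9 percentage points lower from compound 2 to compound 3 (beyond the scatter), both large.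

Compound 4 `Nc1scc(CN2CCN(c3cc(Cl)ccc3Cl)CC2)c1C(=O)c1ccc(Cl)cc1` is not yet measured. Against compound 3 the change is 2,5-dichlorophenyl in place of 2,4-difluorophenyl on an amine nitrogen in a ring. Within the data shown here, the only measured steps touching the 2,4-difluorophenyl group are those into compound 3, each large and downward, but they replace it with an isopropyl or a naphthalen-1-yl group; no measured step exchanges one halogenated six-membered aromatic ring for another, so the effect of this swap has no direct precedent here. Both groups carry two halogens on the same kind of ring, and compound 3 stands far below compounds 1 and 2, so the expectation is that compound 4 remains on the low side, with a modest upward step of about a number 26 percentage points higher from compound 3 to compound 4 (beyond the scatter) allowed for and wide uncertainty. Compound 4 is therefore estimated at -40%, expected to fall between -95% and 15% in this assay.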

Compound 4, a percentage reported as activity, at one concentration (the size of the read-out at that concentration, not a potency): -42%
Compound 4: middle estimate off by 2 percentage points, on the high side; the measured number falls inside the stated range.
By their numbers in this assay, from the lowest: compound 3; then compound 4; then compounds 2 and 1 (each within the scatter of the next).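

In this assay, among these compounds, this is the first step that exchanges one halogenated phenyl group for another on the amine nitrogen in the ring, and it is not neutral: a number 24 percentage points higher from compound 3 to compound 4 (beyond the scatter). The low numbers are also not unique to the 2,4-difluorophenyl group, since the 2,5-dichlorophenyl group still leaves a wide gap to the other two groups: a number 44.9 percentage points lower from compound 2 to compound 4 (beyond the scatter), and a number 49.3 percentage points lower from compound 1 to compound 4 (beyond the scatter), both large steps. Among these four compounds, the two halogenated phenyl groups give the lowest numbers, while compound 2 shows that an aromatic group at this position is not enough on its own, as its naphthalen-1-yl group stays up with the isopropyl group of compound 1, and no measured information explains this difference.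

The step from compound 3 to compound 4 changes the halogen and its placement on the ring together, and the compounds shown do not separate these two changes. They also leave open how a plain phenyl group, or a phenyl group carrying a methoxy group, would read in this assay at this position.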